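The compounds below may be only part of what the source reports. "The series", "measured", "known", "first", "only" and "open" are said of these compounds alone.

Measured so far in an assay on lysate for inhibition of 6-phosphofructo-2-kinase/fructose-2,6-bisphosphatase 3 (Homo sapiens), with stated times of 0.5 min and 45 min; on this read-out lower numbers stand for stronger inhibition and higher numbers for weaker inhibition:

Compound 1 `CNS(=O)(=O)c1ccccc1Nc1cc(-c2ccc3ccn(C)c3c2)c2nccnc2c1` gives a limit of the assay, > 100000 nM.
Compound 2 `CN(C)S(=O)(=O)c1ccccc1Nc1cc(-c2ccc3ccn(C)c3c2)c2nccnc2c1` gives 7670 nM.
Compound 3 `CN(C)C(=O)c1ccncc1Nc1cc(-c2ccc3ccn(C)c3c2)c2nccnc2c1` gives a limit of the assay, > 100000 nM.

Compound 3 therefore stands at the limit of > 100000 nM in this assay, at which 2 of the 3 values shown sit, with no number of its own. Going by the values given here, the only measured step, an at least 13-fold lower number from compound 1 to compound 2 (1.11 log units; beyond the scatter), concerns methyl in place of hydrogen on a sulfonamide nitrogen and says nothing about a change on a carbonyl carbon. Compound 4 `CN1CC(NC(=O)c2ccncc2Nc2cc(-c3ccc4ccn(C)c4c3)c3nccnc3c2)C1` differs from compound 3 by (1-methylazetidin-3-yl)amino in place of dimethylamino on a carbonyl carbon. Among the compounds with values here, no measured step bears on this change, so no direction beyond the scatter is expected in this assay. Compound 4 is expected to remain near the limit, estimated at 100000 nM with a range of 30000 nM to 300000 nM. The expected step is a number no higher from compound 3 to compound 4 (the limit leaves the size open).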

Compound 4, half-maximal inhibitory concentration: 9190 nM
Compound 4: the middle estimate sits 11-fold (1.04 log units) above what was measured; the whole stated range lies above it.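

In this assay, going by these compounds alone, the group on the carbonyl carbon turns out to matter, something the earlier compounds could not show: (1-methylazetidin-3-yl)amino in place of dimethylamino gives an at least 10-fold lower number from compound 3 to compound 4 (1.03 log units; beyond the scatter). Compound 3 has a limit and not a number, so this step has a lower bound but no exact size, and that applies to much of this small set: the limit of > 100000 nM in this assay, at which 2 of the 4 values shown sit.

Going by these compounds, it remains open whether the four-membered ring, the added nitrogen or the amide hydrogen counts most. A simple methylamino group or an open-chain amine such as dimethylaminoethylamino on the same carbonyl carbon could help separate these.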